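A Methyl on the Shared Core, Measured Against Three Limits

The source may hold more compounds than are shown below. What is called first, only, known or untested is meant among the compounds shown, and "the series" means these compounds.

Compound 1 `Nc1nc2ccccn2c1-c1ccc(O)cc1`: > 100000 nM, a limit of the assay
Compound 2 `COc1ccc(-c2c(N)nc3ccccn23)cc1`: > 100000 nM, a limit of the assay
Compound 3 `Cc1ccn2c(-c3ccc(O)cc3)c(N)nc2c1`: > 100000 nM, a limit of the assay

In an assay on isolated protein for inhibition of ubiquitin carboxyl-terminal hydrolase 47 (Homo sapiens) (a higher number here means a weaker inhibitor, a lower number a stronger inhibitor), compound 1 stands only at a limit and not at a number, and every value shown so far sits at that same bound (the limit of > 100000 nM in this assay, at which 3 of the 3 values shown sit). Compound 4 `Cc1cccn2c(-c3ccc(O)cc3)c(N)nc12` differs from compound 1 in one place: methyl in place of hydrogen on an aromatic carbon. Going by the values given here, two measured steps bear on this change. The closest is the step from compound 1 to compound 3, also a methyl entering on an aromatic carbon of the core, which gave a step that the two limits leave unreadable from compound 1 to compound 3. The step that the two limits leave unreadable from compound 1 to compound 2, a methyl on the oxygen instead, is likewise unreadable between the two limits. Neither step gives a direction or a size, so no step beyond the scatter can be read in favour of compound 4, and its value is expected to remain at the limit. The step that the limit leaves unreadable from compound 1 to compound 4 is therefore the expected outcome. For compound 4 the expected value is 150000 nM, within a range from 50000 nM to 500000 nM.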

Compound 4, half-maximal inhibitory concentration: > 100000 nM
Compound 4 gave a limit, no number; the forecaster's own chance of this, stated with the estimate: 85%; the middle value is on the limit's open side.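

Compound 1 and compound 4 both stand only at a limit, so no new step can be read between them: the limit of > 100000 nM in this assay, at which 4 of the 4 values shown sit. The compounds shown leave open whether a methyl on the shared core changes inhibition at all, and in which direction.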